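Lengthening the ester chain by one carbon

The compounds below may be only part of what the source reports. "The series", "measured", "known", "first", "only" and "open" are said of these compounds alone.

Among the measured compounds shown here, compound 2 `CCCCCCCCCCCOC(=O)CCC(=O)N1CCN(CCCOc2cc3c(Nc4ccc(F)c(Cl)c4)ncnc3cc2OC)CC1` gives the lowest of the two numbers so far in a functional assay on A549 cells (Homo sapiens) for cytotoxicity, read by MTT assay, with a stated time of 24 h, tested at 80 uM (a lower number here means a stronger effect, a higher number a weaker effect of the compound at the concentration tested), where compound 2 gives 2.8%. Compound 1 `CCCCCCOC(=O)CCC(=O)N1CCN(CCCOc2cc3c(Nc4ccc(F)c(Cl)c4)ncnc3cc2OC)CC1` carries a shorter ester chain, and in this assay compound 1 gives 42.9%. For the measured compounds named here, the one measured step, a number 40.1 percentage points lower from compound 1 to compound 2 (beyond the scatter), is the only guide here. Compound 3 `CCCCCCCCCCCCOC(=O)CCC(=O)N1CCN(CCCOc2cc3c(Nc4ccc(F)c(Cl)c4)ncnc3cc2OC)CC1` differs from compound 2 by methyl in place of hydrogen on a saturated chain carbon, ten or more bonds along the chain from an oxygen next to a carbonyl group. This is a far smaller change of the same kind than the pentyl step, and compound 2 already sits close to the floor of the read-out, so the account expects no step beyond the scatter in this assay, with the expected step of a number 0.2 percentage points higher from compound 2 to compound 3 (within the scatter) reflecting that. The account therefore estimates that compound 3 will give 3%, within a range from 0% to 12%.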

Compound 3, a percentage reported as activity, at one concentration (the size of the read-out at that concentration, not a potency): 2.3%
Compound 3: middle estimate off by 0.7 percentage points, on the high side, and the stated range covers the measured number.
By their numbers in this assay, from the lowest: compounds 3 and 2 (each within the scatter of the next); then compound 1.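

In this assay, among the compounds shown here, methyl in place of hydrogen on a saturated chain carbon gives a number 0.5 percentage points lower from compound 2 to compound 3 (within the scatter), so this further carbon brings no step like the pentyl one. The full change, hexyl in place of hydrogen, gives a number 40.6 percentage points lower from compound 1 to compound 3 (beyond the scatter), and at this concentration the read-out no longer separates compound 2 from compound 3. Nothing measured here explains how the chain affects the read-out.

Where between the chains of compound 1 and compound 2 the drop arises stays open, as does whether a longer chain, or a chain ending in an amine or a carboxylic acid, would give a similar number. With one concentration, whether compound 2 and compound 3 would differ in the size of their effect at other concentrations also remains unresolved.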